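This account rests on a few compounds, and the source may have more. Where it says the series, first, only, none or still open, it means among the compounds named here.

Measured in an ADME assay on Caco-2 cells (Homo sapiens) for permeability; a higher number here means that the compound crosses the layer faster, a lower number that the compound crosses the layer more slowly:
Compound 1 `CN(C)C(=O)c1cccc(/N=c2\c(O)c(O)\c2=N/c2ccccc2)c1O`: 24 nm/s
Compound 2 `CN(C)C(=O)c1cccc(/N=c2\c(O)c(O)\c2=N/C2CCCC2)c1O`: 101 nm/s

Compound 2 stands higher of the two. Among the measured compounds shown here, the only measured step, a 4.2-fold higher number from compound 1 to compound 2 (0.62 log units; beyond the scatter), is modest but beyond the scatter, and it comes from cyclopentyl in place of phenyl on a double-bonded nitrogen. Compound 3 `CCC(CC)/N=c1\c(O)c(O)\c1=N/c1cccc(C(=O)N(C)C)c1O` changes the same place, with pentan-3-yl in place of cyclopentyl (pentan-3-yl in place of cyclopentyl on a double-bonded nitrogen). For the measured compounds named here, that step bears only loosely, since no measured pair shows the opening of a ring, so no change beyond the scatter is expected in this assay. The expected step is a 1.0-fold lower number from compound 2 to compound 3 (0.00 log units; within the scatter). Compound 3 is estimated at 100 nm/s, within an expected range of 45 nm/s to 210 nm/s.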

Compound 3, apparent permeability: 120 nm/s
Compound 3: the middle estimate sits 1.2-fold (0.08 log units) below what was measured; low and high end bracket the measured number.
By their numbers in this assay, from the lowest: compound 1; then compounds 2 and 3 (each within the scatter of the next).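

In this assay, pentan-3-yl in place of cyclopentyl gives a 1.2-fold higher number from compound 2 to compound 3 (0.07 log units; within the scatter) and so the ring of cyclopentyl can be opened at this position without a change that can be told from the scatter. Pentan-3-yl in place of phenyl gives a 5.0-fold higher number from compound 1 to compound 3 (0.70 log units; beyond the scatter) and so a second non-aromatic group, this one without a ring, stands clear of phenyl. No evidence is available on what lies behind these numbers.

The compounds shown leave open whether a shorter or longer chain would match pentan-3-yl here. They also leave open how an amine or a carboxylic acid at this position would read.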